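The compounds below may be only part of what the source reports. "The series", "measured", "known", "first", "only" and "open" are said of these compounds alone.

Compound 1 `CC/C=C/C(=O)Nc1cccc(Oc2nc(Nc3cccc(OC)c3)nc3c2CSCC3)c1`: > 50000 nM, a limit.
Compound 2 `COc1cccc(Nc2nc3c(c(Oc4cccc(NC(=O)C=C(C)C)c4)n2)CSCC3)c1`: > 50000 nM, a limit.

Both entries come from an ADME assay on L02 cells (Homo sapiens) for cytotoxicity, read by MTT assay, with a stated time of 72 h; a higher number here means a weaker inhibitor, a lower number a stronger inhibitor. Compound 2 therefore stands at a limit and has no number.

Compound 3 `C=C(F)C(=O)Nc1cccc(Oc2nc(Nc3cccc(OC)c3)nc3c2CSCC3)c1` carries 1-fluoroethenyl in place of 2-methylprop-1-en-1-yl on a carbonyl carbon. Among the compounds with values here, the only measured step is a step that the two limits leave unreadable from compound 1 to compound 2, so it offers no size to carry over. Within the data shown here, the sole guide is the limit of > 50000 nM in this assay, at which 2 of the 2 values shown sit, and another limit is the likeliest result in this assay, with no direction firmly expected. The expected step is an at least 1.1-fold lower number from compound 2 to compound 3 (0.04 log units; that floor lies within the scatter). Compound 3 is estimated at 45000 nM, with an expected range of 15000 nM to 100000 nM.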

Compound 3, half-maximal inhibitory concentration: 41200 nM
Compound 3: the middle estimate sits 1.1-fold (0.04 log units) above what was measured; the range from low to high includes it.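

In this assay, 1-fluoroethenyl in place of 2-methylprop-1-en-1-yl on a carbonyl carbon gives an at least 1.2-fold lower number from compound 2 to compound 3 (0.08 log units; that floor lies within the scatter). Against but-1-en-1-yl, the same group gives an at least 1.2-fold lower number from compound 1 to compound 3 (0.08 log units; that floor lies within the scatter). Compound 3 is the only compound here with a number rather than a limit, yet both floors lie within the scatter, so no real effect of this change is shown: the limit of > 50000 nM in this assay, at which 2 of the 3 values shown sit.

As far as these compounds go, the true size of either step remains open. So does how a longer chain carrying a dimethylamino group on the same carbonyl carbon would read in this assay.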